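The source may hold more compounds than are shown below. What is called first, only, known or untested is meant among the compounds shown, and "the series" means these compounds.

Series notes. Compound 1 `Cc1cn2cccc(OCc3ccccc3)c2n1` gives 70% in a functional assay on the whole organism (stomach) for inhibition, with Canis familiaris (Canis lupus familiaris) as the target, at a dose of 5 mg/kg by the intravenous route; on this read-out higher numbers stand for a stronger effect at the one dose given and lower numbers for a weaker effect. Compound 2 `CCOCc1c(C)nc2c(OCc3ccccc3)cccn12` gives 35% in this assay. Compound 3 `Cc1nc2c(OCc3ccccc3)cccn2c1Cl` gives 37% in this assay. Among these three numbers compound 3 stands second highest; its nearest neighbour is compound 2, and the two lie within the scatter of each other, while its furthest is compound 1, the step being a number 33 percentage points lower from compound 1 to compound 3 (beyond the scatter). The other step onto compound 3, a number 2 percentage points higher from compound 2 to compound 3 (within the scatter), is within the scatter.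

Compound 4 `Cc1nc2c(OCc3ccccc3)cccn2c1Br` differs from compound 3 by bromo in place of chloro on an aromatic carbon. Within the data shown here, no measured step exchanges one halogen for another. The step of a number 33 percentage points lower from compound 1 to compound 3 (beyond the scatter) concerns the same place, but sets chloro against hydrogen; the step of a number 2 percentage points higher from compound 2 to compound 3 (within the scatter) sets chloro against ethoxymethyl there without a change beyond the scatter. With no exchange of this kind measured, no step beyond the scatter is expected in this assay, in either direction. Compound 4 is therefore expected at 37%, with a range from 20% to 55%. The expected step of no change at the digits printed from compound 3 to compound 4 (within the scatter) is estimated to stay within the scatter.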

Compound 4, a percentage reported as inhibition, in the whole organism at one dose (the size of the read-out at that dose, not a potency): 63%
Compound 4: the middle estimate sits 26 percentage points below what was measured, outside the stated range (above it).
By their numbers in this assay, from the lowest: compounds 2 and 3 (each within the scatter of the next); then compounds 4 and 1 (each within the scatter of the next).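

Among these compounds, on the aromatic carbon of the five-membered ring, the two halogens are not interchangeable in this assay: exchanging chloro for bromo gives a number 26 percentage points higher from compound 3 to compound 4 (beyond the scatter) and is the first halogen exchange seen. Bromo also separates from ethoxymethyl at this carbon, with a number 28 percentage points higher from compound 2 to compound 4 (beyond the scatter) as the step, whereas chloro did not. A substituent here therefore need not lower the read-out, since replacing hydrogen with bromo gives a number 7 percentage points lower from compound 1 to compound 4 (within the scatter) and leaves the two compounds unresolved, unlike the chloro and ethoxymethyl replacements.

As far as these compounds go, what separates bromo from chloro remains open, as no measurement here bears on it. Also open, from the compounds shown here alone, is whether iodo, methyl or a nitrile on this carbon would stand with bromo or with chloro in this assay.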